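The source may report more compounds than this note shows. Statements on the series, on what has been measured and on what is new or still open speak of the compounds shown alone.

Compound 1 `CC(C)(C)NCc1c(C(=O)O)nn(-c2ccccc2)c1-c1ccc(F)cc1`: > 680000 nM (a limit)
Compound 2 `CC(C)(C)NCc1c(C(=O)O)nn(-c2ccccc2)c1-c1ccc(Br)cc1`: 293000 nM
Compound 3 `Cc1ccc(-c2c(CNC(C)(C)C)c(C(=O)O)nn2-c2ccccc2)cc1`: > 688000 nM (a limit)

These three compounds were tested in a functional assay on MCF7 cells (Homo sapiens) for inhibition, read by sulforhodamine B assay, with a stated time of 48 h (a lower number here means a stronger inhibitor of growth, a higher number a weaker inhibitor of growth), and they differ only in one group on an aromatic ring. Compound 3 has no exact value, only the limit > 688000 nM. Compound 1 also reached only a limit, so compound 2 alone gave a true number.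

Compound 4 `COc1ccc(-c2c(CNC(C)(C)C)c(C(=O)O)nn2-c2ccccc2)cc1` has methoxy in place of methyl on an aromatic carbon, para to a large group, turning 4-methylphenyl into 4-methoxyphenyl: methoxy in place of methyl on an aromatic carbon.

The three measured swaps at this same place are the closest guide. Putting bromo in place of fluoro gave an at least 2.3-fold lower number from compound 1 to compound 2 (0.36 log units; beyond the scatter). Putting methyl in place of bromo gave an at least 2.3-fold higher number from compound 2 to compound 3 (0.37 log units; beyond the scatter). Putting methyl in place of fluoro gave a step that the two limits leave unreadable from compound 1 to compound 3. Both readable steps involve compound 2, and they are modest at the least. Methoxy has not been tested here, so these swaps offer no reason to expect a large gain over compound 3. No step beyond the scatter is expected, and compound 4 may well reach a limit too. The expected change is an at least 1.1-fold lower number from compound 3 to compound 4 (0.05 log units; that floor lies within the scatter). For compound 4 the estimated value is 600000 nM, with an expected range from 250000 nM to 1000000 nM.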

Compound 4, concentration for 50% growth inhibition: > 659000 nM
Compound 4: only a limit was reported; the forecaster's own chance of this, stated with the estimate: 60%; middle value at least 1.0-fold (0.04 log units) from the limit.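

In this assay, compound 4 reached only a limit, > 659000 nM, so methoxy joins fluoro and methyl at this position, and among these four compounds bromo alone gave a true number. Putting methoxy in place of bromo gave an at least 2.2-fold higher number from compound 2 to compound 4 (0.35 log units; beyond the scatter), so compound 2 now stands apart from all three other compounds by a step beyond the scatter, and the change from 4-methylphenyl to 4-methoxyphenyl brought no measurable gain in growth inhibition. The steps from compound 3 to compound 4 and from compound 1 to compound 4 cannot be read, and how far compound 4 truly lies from those two stays unknown: the limit of > 659000 nM in this assay, at which 1 of the 4 values shown sits.

The compounds shown leave open whether the advantage of compound 2 belongs to bromo alone or would also appear with chloro, iodo or trifluoromethyl at this same place. They also leave open what an amine or a longer chain would do there, and whether any group on this ring could bring the number far under that of compound 2, which gave 293000 nM.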